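The compounds below may be only part of what the source reports. "The series", "measured", "known", "first", "only" and "open" are said of these compounds alone.

Of the compounds shown here, three of one series have been measured in an ADME assay on Vero cells (Chlorocebus sabaeus) for cytotoxicity, with a stated time of 5 days; on this read-out higher numbers stand for weaker inhibition and lower numbers for stronger inhibition. Compound 1 `Cc1ccc(C2=NNC(c3ccc(N4CCCCC4)cc3)C2)s1` gives 52000 nM in this assay. Compound 2 `Cc1cc(C2=NNC(c3ccc(N4CCCCC4)cc3)C2)c(C)s1` gives 83400 nM in this assay, and the step of a 1.6-fold higher number from compound 1 to compound 2 (0.21 log units; within the scatter) lies within the scatter. For compound 3 `Clc1ccc(C2=NNC(c3ccc(N4CCCCC4)cc3)C2)s1` this assay reports only a limit, > 100000 nM. Compound 3 thus stands at the edge of what this assay can report, with no number of its own. The steps of an at least 1.9-fold higher number from compound 1 to compound 3 (0.28 log units; that floor lies within the scatter) and an at least 1.1-fold higher number from compound 2 to compound 3 (0.07 log units; that floor lies within the scatter) both rest on that limit of > 100000 nM in this assay, at which 1 of the 3 values shown sits, and give only a floor that lies within the scatter.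

Compound 4 `Ic1ccc(C2=NNC(c3ccc(N4CCCCC4)cc3)C2)s1` differs from compound 3 by iodo in place of chloro on an aromatic carbon. Among the compounds with values here, no measured step exchanges one halogen for another, so the nearest comparisons are an at least 1.9-fold higher number from compound 1 to compound 3 (0.28 log units; that floor lies within the scatter) and an at least 1.1-fold higher number from compound 2 to compound 3 (0.07 log units; that floor lies within the scatter), neither of which rises beyond the scatter. A step beyond the scatter in either direction is therefore not expected. Compound 4 is estimated at 120000 nM in this assay, between 55000 nM and 260000 nM. For compound 4 this estimate means an expected step that the limit leaves unreadable from compound 3 to compound 4.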

Compound 4, half-maximal inhibitory concentration: 15900 nM
Beside the measured number, compound 4's estimate is 7.5-fold (0.88 log units) above it, outside the stated range (below it).
By their numbers in this assay, from the lowest: compound 4; then compounds 1 and 2 (each within the scatter of the next). At a limit, above all of these: compound 3.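

In this assay, within the data shown here, exchanging chloro for iodo on this aromatic carbon next to the ring sulfur gives an at least 6.2-fold lower number from compound 3 to compound 4 (0.79 log units; beyond the scatter), a step beyond the scatter, which none of the earlier steps was. The size of that step is only a floor, and it rests on a limit: the limit of > 100000 nM in this assay, at which 1 of the 4 values shown sits. Iodo also separates from the methyl-bearing thiophenes, with a 3.3-fold lower number from compound 1 to compound 4 (0.51 log units; beyond the scatter) and a 5.2-fold lower number from compound 2 to compound 4 (0.72 log units; beyond the scatter), so this position can move the read-out, and compound 4 has the lowest number of the series.

With only methyl, chloro and iodo shown on this carbon, the compounds leave open where bromo or fluoro would fall. They also leave open whether a methoxy group or a nitrile on the same carbon would give a number as low as iodo does.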